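The source may report more compounds than this note shows. Statements on the series, on what has been measured and on what is new or still open speak of the compounds shown alone.

Compound 1 `CC(C(=O)O)c1nn(Cc2cn3cc(OCC4CC4)c(Cl)cc3n2)c2ccccc2c1=O`: < 8.34 mL/min/kg, a limit
Compound 2 `O=C(O)Cn1nc(Cn2cc3cc(OCC4CC4)c(Cl)cc3n2)c2ccccc2c1=O`: < 11.7 mL/min/kg, a limit
Compound 3 `CC(C(=O)O)c1nn(Cc2cn3cc(OCC4CC4)c(C(F)(F)F)cc3n2)c2ccccc2c1=O`: < 8.34 mL/min/kg, a limit

In an ADME assay on cells (Hepatocyte, Homo sapiens) for metabolic stability, read by LC-MS, with a stated time of 180 min, tested at 1 uM (a lower number here means slower removal, a higher number faster removal of the compound), none of the three compounds has yielded a number. Compound 1 stands at the limit of < 8.34 mL/min/kg in this assay, at which 2 of the 3 values shown sit. Compound 2 stands at the limit of < 11.7 mL/min/kg in this assay, at which 1 of the 3 values shown sits.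

The next compound is compound 4 `CCC(C(=O)O)c1nn(Cc2cn3cc(OCC4CC4)c(Cl)cc3n2)c2ccccc2c1=O`, which differs from compound 1 as follows: methyl in place of hydrogen on a saturated chain carbon, two bonds along the chain from an aromatic carbon and a carbonyl carbon. The side chain thus goes from 1-carboxyethyl to 1-carboxypropyl, with methyl becoming ethyl.

For the measured compounds named here, the only measured step is a step that the two limits leave unreadable from compound 1 to compound 3. Going by the values given here, it is a different change and gives no size to carry over, so no measured step bears directly on this one. The expectation rests on compound 1 alone, whose limit is < 8.34 mL/min/kg. No step beyond the scatter is expected in this assay, and another limit is a likely report. The expected step is a step that the limit leaves unreadable from compound 1 to compound 4. For compound 4 the estimated clearance is 6 mL/min/kg, with an expected range of 3 mL/min/kg to 12 mL/min/kg.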

Compound 4, clearance: < 8.34 mL/min/kg
Compound 4 was reported as a limit; the forecaster's own chance of this, stated with the estimate: 75%; the middle value does not contradict the limit.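

In this assay compound 4, like compound 1, is reported only as a limit, and the step between these two compounds cannot be read. The compounds shown leave open how fast any of them is removed, and whether methyl in place of hydrogen changes that at all.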